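Ether chain terminus in the quinazoline piperidine series

The compounds below may be only part of what the source reports. "The series", "measured", "known", "first", "only" and "open" are said of these compounds alone.

The series keeps one core and varies the group on the far oxygen of the ether chain. Compound 1 `COCCOC1CCN(c2nc(N)c3cc(OC)c(OC)cc3n2)CC1` gives 2.12 nM in an assay on brain for displacement of a labelled ligand from Adrenergic receptor alpha-1 (Rattus norvegicus); a higher number here means a weaker inhibitor, a lower number a stronger inhibitor. Compound 2 `CCOCCOC1CCN(c2nc(N)c3cc(OC)c(OC)cc3n2)CC1` gives 1.81 nM in this assay, and compound 3 `COc1cc2nc(N3CCC(OCCOC(C)C)CC3)nc(N)c2cc1OC` gives 0.67 nM. Compound 3 has the lowest number of the three, beyond the scatter from both others. The steps show a 1.2-fold lower number from compound 1 to compound 2 (0.07 log units; within the scatter), a 3.2-fold lower number from compound 1 to compound 3 (0.50 log units; beyond the scatter) and a 2.7-fold lower number from compound 2 to compound 3 (0.43 log units; beyond the scatter).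

Compound 4 `COc1cc2nc(N3CCC(OCCOc4ccccc4)CC3)nc(N)c2cc1OC` differs from compound 3 by phenyl in place of isopropyl on an oxygen on a saturated carbon. Within the data shown here, the steps that bear on it are those that enlarge the group on that oxygen: the step from compound 1 to compound 3 and the step from compound 2 to compound 3, both modest and beyond the scatter, whereas the step from compound 1 to compound 2 stays within it. Among the measured compounds shown here, no measured step introduces a ring at this place, so the direction is only weakly supported. A further modest lowering or no step beyond the scatter is expected, giving a 1.5-fold lower number from compound 3 to compound 4 (0.17 log units; within the scatter) in this assay. Compound 4 is estimated at 0.45 nM, between 0.15 nM and 1.5 nM.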

Compound 4, inhibition constant: 0.48 nM
Estimate against measurement, compound 4: 1.1-fold (0.03 log units) below, within the range that was stated.
By their numbers in this assay, from the lowest: compounds 4 and 3 (each within the scatter of the next); then compounds 2 and 1 (each within the scatter of the next).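

In this assay, the oxygen on a saturated carbon also accepts an aromatic ring: phenyl in place of isopropyl gives a 1.4-fold lower number from compound 3 to compound 4 (0.14 log units; within the scatter), so the two groups cannot be separated here. Compared with the smaller groups, phenyl gives a 3.8-fold lower number from compound 2 to compound 4 (0.58 log units; beyond the scatter) and a 4.4-fold lower number from compound 1 to compound 4 (0.65 log units; beyond the scatter), so the low numbers at this position are no longer confined to the branched isopropyl group. Nothing available on these compounds accounts for these steps.

Still open, from the compounds shown here alone, is whether a phenyl ring carrying a chlorine or a methoxy group would stay in the range of compound 4. The same applies to a benzyl group, a longer chain in place of 2-phenoxyethyl, or an amine or carboxylic acid at the end of the chain.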